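This account rests on a few compounds, and the source may have more. Where it says the series, first, only, none or still open, it means among the compounds named here.

Compound 1 `COC(=O)c1sc2cc(OC)ccc2c1C#Cc1ccc(F)cc1` gives 20900 nM in a functional assay on NCI-H460 cells (Homo sapiens) for cytotoxicity, read by sulforhodamine B assay, with a stated time of 48 h (on this read-out higher numbers stand for weaker inhibition of growth and lower numbers for stronger inhibition of growth), the second highest of three numbers. Compound 2 `COC(=O)c1sc2cc(OC)ccc2c1C#Cc1ccccc1F` gives 7200 nM, and compound 3 `COC(=O)c1sc2ccccc2c1C#Cc1ccccc1` gives 64700 nM. For the measured compounds named here, the only single-site step measured is a 2.9-fold lower number from compound 1 to compound 2 (0.46 log units; beyond the scatter), which concerns the fluorophenyl group rather than the core. Compound 4 `COC(=O)c1sc2ccccc2c1C#Cc1ccc(F)cc1` differs from compound 1 by hydrogen in place of methoxy on an aromatic carbon. Going by the values given here, no measured step isolates this change; compound 3, which lacks both the methoxy and the fluorine, shows a higher number than compound 1. On that basis compound 4 is expected to give a higher number than compound 1, estimated at 40000 nM with a range from 15000 nM to 110000 nM, a step of a 1.9-fold higher number from compound 1 to compound 4 (0.28 log units; within the scatter) that is expected to be modest.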

Compound 4, concentration for 50% growth inhibition: 76100 nM
Beside the measured number, compound 4's estimate is 1.9-fold (0.28 log units) below it, within the range that was stated.
By their numbers in this assay, from the lowest: compound 2; then compound 1; then compounds 3 and 4 (each within the scatter of the next).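

Hydrogen in place of methoxy on this aromatic carbon now has a step of its own with the 4-fluorophenyl group held constant: in this assay it gives a 3.6-fold higher number from compound 1 to compound 4 (0.56 log units; beyond the scatter). Without the methoxy, fluoro in place of hydrogen changes little, at a 1.2-fold higher number from compound 3 to compound 4 (0.07 log units; within the scatter). Nothing measured here explains the methoxy step. Going by these compounds, whether a hydroxyl, an ethoxy or an amine on this carbon would give a lower or a higher number stays open. So does whether removing the methoxy would have a similar effect alongside the 2-fluorophenyl group of compound 2.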